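The source may report more compounds than this note shows. Statements on the series, on what has been measured and on what is new or still open speak of the compounds shown alone.

Of the compounds shown here, three sharing one core have been tested in an ADME assay on BJ cells (Homo sapiens) for cytotoxicity, with a stated time of 72 h; a lower number here means that less compound is needed, a higher number that more compound is needed for the effect: compound 1 `COc1cc2ncnc(-n3nc(-c4ccccn4)nc3N)c2cc1OCc1ccccc1`, compound 2 `COc1cc2ncnc(-n3nc(-c4ccccn4)nc3N)c2cc1OCCCCNC(=O)OC(C)(C)C` and compound 3 `COc1cc2ncnc(-n3nc(-c4ccccn4)nc3N)c2cc1OCCNC(=O)OC(C)(C)C`. Compound 1 gives only a limit, > 27000 nM. Compound 2 also gives only a limit, > 7000 nM. Compound 3 likewise stands at a limit, > 15000 nM, so no number ranks it against the other two. Compound 4 `COc1cc2ncnc(-n3nc(-c4ccccn4)nc3N)c2cc1OCCCNC(=O)OC(C)C` differs from compound 3 by ((isopropoxycarbonyl)amino)methyl in place of (tert-butoxycarbonyl)amino on a saturated chain carbon, two bonds along the chain from an oxygen on an aromatic ring, with ((isopropoxycarbonyl)amino)methyl in place of (tert-butoxycarbonyl)amino on a saturated chain carbon. The measured chain changes bearing on this are a step that the two limits leave unreadable from compound 2 to compound 3 and a step that the two limits leave unreadable from compound 1 to compound 3; neither has a readable size, so neither indicates a direction. The expected result is a number no higher from compound 3 to compound 4 (the limit leaves the size open), with no shift beyond the scatter in this assay. For compound 4 the estimated value is 15000 nM, ranging from 6000 nM to 35000 nM, and it may well be reported as a limit.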

Compound 4, half-maximal effective concentration: > 13000 nM
Compound 4 was reported as a limit; the forecaster's own chance of this, stated with the estimate: 85%; the middle value does not contradict the limit.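

Within the data shown here, compound 4 gives only a limit, as do compound 1, compound 2 and compound 3, so no step among them can be read. The compounds shown leave open whether these side chains differ at all, and in which direction.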